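This account rests on a few compounds, and the source may have more. Where it says the series, first, only, none or still open, it means among the compounds named here.

Measured in a functional assay on MCF7 cells (Homo sapiens) for inhibition, read by colorimetric assay and MTT assay, with a stated time of 72 h; on this read-out higher numbers stand for weaker inhibition and lower numbers for stronger inhibition:
- Compound 1 `CCCCCCOc1ncc(-c2ccccc2OC)n1C`: 27000 nM
- Compound 2 `COc1ccccc1-c1cnc(OC)n1C`: > 100000 nM (a limit of the assay)

Compound 2 stands at > 100000 nM, which is a limit and not a number. Compound 3 `C=CCCOc1ncc(-c2ccccc2OC)n1C` differs from it as follows: allyl in place of hydrogen on a saturated chain carbon bound to an oxygen on an aromatic ring. This puts allyl in place of hydrogen on a saturated chain carbon bound to an oxygen on an aromatic ring. Among the compounds with values here, the one measured step that bears on this change runs the opposite way, with hydrogen replacing pentyl at that place: an at least 3.7-fold higher number from compound 1 to compound 2 (0.56 log units; beyond the scatter). Allyl is the smaller addition, so a partial return toward compound 1 is expected in this assay. The expected change is an at least 2.0-fold lower number from compound 2 to compound 3 (0.30 log units; that floor lies within the scatter), toward stronger inhibition. Compound 3 is estimated at 50000 nM, with an expected range from 24000 nM to 100000 nM.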

Compound 3, half-maximal inhibitory concentration: 27000 nM
Estimate against measurement, compound 3: 1.9-fold (0.27 log units) above; the range from low to high includes it.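

In this assay, allyl in place of hydrogen on the saturated chain carbon bound to the oxygen gives an at least 3.7-fold lower number from compound 2 to compound 3 (0.56 log units; beyond the scatter), so the smaller addition already brings the value off the limit. Compound 2 stands at > 100000 nM, which is a limit of the assay and not a number. Vinyl in place of butyl, two bonds along the chain from the oxygen, gives no change at the digits printed from compound 1 to compound 3 (within the scatter), so this read-out does not separate the two chains.

As far as these compounds go, whether a longer chain, or an amine or a carboxylic acid at the chain end, would shift the value remains open. The step from compound 2 also gives only a floor, not a full size: the limit of > 100000 nM in this assay, at which 1 of the 3 values shown sits.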